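A few compounds are considered here, and "the series" means these few. Any claim that something is new, unique, unknown or untested is made for them only; others in the source may bear on it.

The series shares one core, seen in compound 1 `O=c1[nH]cc(S(=O)(=O)Nc2cccc(-c3cn(-c4ccccc4F)nn3)c2)c(=O)[nH]1` and in compound 2 `O=c1[nH]cc(S(=O)(=O)Nc2cccc(-c3cn(-c4cccc(F)c4)nn3)c2)c(=O)[nH]1`, each carrying a fluorophenyl on the triazole nitrogen. In an ADME assay on GES1 cells (Homo sapiens) for cytotoxicity, read by MTT assay, with a stated time of 24 h (on this read-out lower numbers stand for higher toxicity in this test and higher numbers for lower toxicity in this test), compound 1 is reported as "not toxic" (no number reported) and compound 2 likewise as "not toxic" (no number reported), so neither gives a number to compare. Within the data shown here, compound 3 `O=c1[nH]cc(S(=O)(=O)Nc2cccc(-c3cn(-c4ccccc4Cl)nn3)c2)c(=O)[nH]1` is the only member with a figure: in this assay compound 3 gives 14000 nM, the single value against which anything else can be set.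

Compound 4 `O=c1[nH]cc(S(=O)(=O)Nc2cccc(-c3cn(-c4ccc(Cl)cc4)nn3)c2)c(=O)[nH]1` is not yet measured. The change from compound 3 is 4-chlorophenyl in place of 2-chlorophenyl on an aromatic nitrogen. Among the measured compounds shown here, no measured pair in this set shows what moving a halogen around that ring does, and the fluoro analogues offer no number. With nothing to anchor a shift, the expectation is a step from compound 3 to compound 4 of no change at the digits printed from compound 3 to compound 4 (within the scatter), within the usual scatter. Compound 4 is therefore expected to give about 14000 nM in this assay, between 6000 nM and 35000 nM.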

Compound 4, half-maximal cytotoxic concentration: 11300 nM
Compound 4: the middle estimate sits 1.2-fold (0.09 log units) above what was measured; low and high end bracket the measured number.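

In this assay, among these compounds, the numbers show a 1.2-fold lower number from compound 3 to compound 4 (0.09 log units; within the scatter) and so give the first numerical comparison at this position, on an aromatic nitrogen of the five-membered ring. Within this pair, 4-chlorophenyl in place of 2-chlorophenyl does not separate compound 3 from compound 4 in this read-out. Nothing given here offers an explanation for this result.

On these data alone, both compounds with numbers carry a chlorophenyl group, so it remains open whether a phenyl bearing an amine, a carboxylic acid or a methoxy group would give a number apart from theirs. As far as these compounds go, the fluorophenyl compounds also remain open, as compound 1 and compound 2 have no numbers and cannot show whether moving fluorine on the ring matters in this assay.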